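The source may hold more compounds than are shown below. What is called first, only, known or untested is meant among the compounds shown, and "the series" means these compounds.

Measured compounds in a functional assay on HT-29 cells (Homo sapiens) for inhibition, read by MTT assay, with a stated time of 48 h; a lower number here means a stronger inhibitor, a higher number a weaker inhibitor:
compound 1 `O=C1CN(C2CCCC2)c2nc(Nc3ccc(N4CCCCC4)cn3)ncc2N1` gives 21100 nM;
compound 2 `CC1CCN(c2ccc(Nc3ncc4c(n3)N(C3CCCC3)CC(=O)N4)nc2)CC1` gives only a limit of the assay, > 30000 nM;
compound 3 `O=C1CN(C2CCCC2)c2nc(Nc3ccc(N4CCNCC4)cn3)ncc2N1` gives only a limit of the assay, > 30000 nM.

Compound 2 therefore stands at the ceiling of this assay, (the limit of > 30000 nM in this assay, at which 2 of the 3 values shown sit), with no number of its own. Compound 4 `CC1CCN(c2ccc(Nc3ncc4c(n3)N(C3CCCC3)CC(=O)N4C)nc2)CC1` differs from compound 2 by methyl in place of hydrogen on an amide-type nitrogen in a ring. Among the measured compounds shown here, none of the measured steps touches this position: an at least 1.4-fold higher number from compound 1 to compound 2 (0.15 log units; that floor lies within the scatter) concerns a saturated ring carbon, an at least 1.4-fold higher number from compound 1 to compound 3 (0.15 log units; that floor lies within the scatter) the aromatic ring, and a step that the two limits leave unreadable from compound 2 to compound 3. No guidance on methylating the amide hydrogen therefore exists within the series. The expected step is a step that the limit leaves unreadable from compound 2 to compound 4, that is, none that can be read beyond the scatter. Compound 4 is estimated at 40000 nM, range 15000 nM to 150000 nM, most likely again reported only as a limit.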

Compound 4, half-maximal inhibitory concentration: 11300 nM
For compound 4 the middle estimate is 3.5-fold (0.55 log units) above the measured one; the measured number lies below the stated range.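

In this assay, among the compounds shown here, methyl in place of hydrogen on this amide-type nitrogen in a ring gives an at least 2.6-fold lower number from compound 2 to compound 4 (0.42 log units; beyond the scatter) and is the first change to lower the number beyond the scatter. The position is therefore open to change, and the amide hydrogen is not needed for a measurable value in this assay. The size remains a floor only, because compound 2 has no number of its own: the limit of > 30000 nM in this assay, at which 2 of the 4 values shown sit.

On these data alone, whether the same methyl would act similarly on compound 1 or compound 3 remains open. Also open, as far as these compounds go, is how an ethyl group, a longer chain or a chain ending in an amine would behave on this nitrogen.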